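A few compounds are considered here, and "the series" means these few. Any claim that something is new, unique, unknown or untested is made for them only; others in the source may bear on it.

Compound 2 `Cc1n[nH]c2ccc(-c3nc4cnc(N5CCN(C)CC5)cn4c3Nc3ccc(Br)cc3)cc12` stands highest of the two numbers in a functional assay on MV4-11 cells (Homo sapiens) for inhibition, with a stated time of 120 h, tested at 10 uM (on this read-out higher numbers stand for more inhibition at the one concentration tested (going by the name of the read-out) and lower numbers for less inhibition), where compound 2 gives 83%. Compound 1 `Cc1n[nH]c2ccc(-c3nc4cnc(N5CCN(C)CC5)cn4c3Nc3ccccc3Cl)cc12` gives 58.1%, and the step of a number 24.9 percentage points higher from compound 1 to compound 2 (beyond the scatter) went with 4-bromophenyl in place of 2-chlorophenyl on a nitrogen on an aromatic ring. Compound 3 `Cc1n[nH]c2ccc(-c3nc4cnc(N5CCN(C)CC5)cn4c3Nc3ccccc3)cc12` differs from compound 2 by hydrogen in place of bromo on an aromatic carbon. No measured step removes bromo alone; the one step shown swapped one halophenyl for another, so it bears only loosely here. Compound 3 is therefore expected to sit somewhat lower, a step of a number 18 percentage points lower from compound 2 to compound 3 (beyond the scatter), giving an estimated 65% with a range from 45% to 85%.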

Compound 3, a percentage reported as inhibition, at one concentration (the size of the read-out at that concentration, not a potency): 0%
Compound 3: the middle estimate sits 65 percentage points above what was measured, and the stated range ends above it.
By their numbers in this assay, from the lowest: compound 3; then compound 1; then compound 2.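

In this assay, hydrogen in place of bromo on the aromatic carbon para to a large group gave a number 83 percentage points lower from compound 2 to compound 3 (beyond the scatter), so the read-out depends on this substituent, which the swap of one halophenyl for another could not show. Hydrogen in place of chloro likewise gave a number 58.1 percentage points lower from compound 1 to compound 3 (beyond the scatter), so both halogen-bearing compounds stand clear of the bare anilino compound. Nothing available explains this loss. Open, from the compounds shown here alone, is whether only a halogen serves here, or whether a methoxy, a methyl or an amine at the same carbon would also hold the read-out.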